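The source may report more compounds than this note shows. Statements on the series, on what has been measured and on what is new or still open speak of the compounds shown alone.

Two compounds have been measured in an ADME assay on PC-3 cells (Homo sapiens) for cytotoxicity, read by WST assay, tested at 100 uM; a lower number here means less inhibition, a higher number more inhibition at the concentration tested (going by the name of the read-out):

Compound 1, `O=C(Nc1cccc(CN2CCCC2)c1)C1CCCN(C(=O)c2cc(C(F)(F)F)cc(C(F)(F)F)c2)C1`: compound 1 gives 51%
Compound 2, `COCc1cccc(C(=O)N2CCCC(C(=O)Nc3ccc(Cl)cc3)C2)c1`: compound 2 gives 0%

For the measured compounds named here, compound 1 stands as the higher of the two numbers in this assay; compound 2, the only other compound measured, lies far below it, and that gap is beyond the usual scatter. Going by the values given here, compound 2 differs from compound 1 in several places at once, so no single step between measured compounds is available.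

Compound 3, `O=C(Nc1cccc(Cc2ccccc2)c1)C1CCCN(C(=O)c2cc(C(F)(F)F)cc(C(F)(F)F)c2)C1`, is not yet measured. Compared with compound 1 the difference is phenyl in place of pyrrolidin-1-yl on a saturated chain carbon bound to an aromatic carbon. The rest of the shared core is kept. Among the compounds with values here, with no comparable step among the measured compounds, the expected step in this assay from compound 1 to compound 3 is small, in either direction, and probably not beyond the scatter. Compound 3 is therefore estimated to give 45%, within a range of 15% to 75%, an expected change of a number 6 percentage points lower from compound 1 to compound 3 (within the scatter).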

Compound 3, a percentage reported as inhibition, at one concentration (the size of the read-out at that concentration, not a potency): 0%
Beside the measured number, compound 3's estimate is 45 percentage points above it; measured number outside the range, below it.
By their numbers in this assay, from the lowest: compounds 2 and 3 (each within the scatter of the next); then compound 1.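

Swapping pyrrolidin-1-yl for phenyl on a saturated chain carbon bound to an aromatic carbon gives the first comparison at a single place in this assay, and the result is a number 51 percentage points lower from compound 1 to compound 3 (beyond the scatter). The earlier compounds shown here differed in several places at once, whereas here the rest of the shared core is kept, so this one place alone can carry a large change in the read-out. No available measurement gives a reason for the step.

As far as these compounds go, it remains open whether the nitrogen of the pyrrolidine ring matters or the ring as a whole. A dimethylamino group or a piperidin-1-yl group at the same place would help separate these two readings, and a morpholin-4-yl group would show how a ring oxygen fits in.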